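Replacing the halogenated phenyl with a bicyclic aromatic group

The source may hold more compounds than are shown below. What is called first, only, known or untested is meant among the compounds shown, and "the series" means these compounds.

Measured compounds:
compound 1, `CC1=C(CC(=O)NCCN(C)C)c2cc(F)ccc2/C1=C\c1ccc(Cl)cc1`, 12400 nM
compound 2, `CC1=C(CC(=O)NCCN(C)C)c2cc(F)ccc2/C1=C\c1ccc(Br)cc1`, 20000 nM

In a functional assay on HT-29 cells (Homo sapiens) for antiproliferative activity, read by MTT assay, with a stated time of 72 h (a lower number here means a stronger inhibitor, a higher number a weaker inhibitor), compound 1 gives 12400 nM and compound 2 gives 20000 nM; the two differ only in the halogen on the aromatic carbon, and the step of a 1.6-fold higher number from compound 1 to compound 2 (0.21 log units; within the scatter) lies within the scatter, so compound 2 cannot be called weaker than compound 1 on these numbers. Compound 3, `CC1=C(CC(=O)NCCN(C)C)c2cc(F)ccc2/C1=C\c1ccc2ccccc2c1`, carries naphthalen-2-yl in place of 4-bromophenyl on a double-bonded chain carbon bound to a double-bonded ring carbon. Going by the values given here, no measured step bears on this change: the only step known, a 1.6-fold higher number from compound 1 to compound 2 (0.21 log units; within the scatter), swaps one halogen for another and leaves the ring count untouched, whereas the change to compound 3 adds a second aromatic ring and removes the bromine. With nothing to anchor a direction, the expected step of a 1.3-fold lower number from compound 2 to compound 3 (0.12 log units; within the scatter) in this assay is kept small relative to the wide uncertainty. Compound 3 is therefore estimated at 15000 nM, with a range from 3000 nM to 60000 nM.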

Compound 3, half-maximal inhibitory concentration: 271000 nM
Compound 3: middle estimate off by 18-fold (1.26 log units), on the low side, outside the stated range (above it).
By their numbers in this assay, from the lowest: compounds 1 and 2 (each within the scatter of the next); then compound 3.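

In this assay, the place on a double-bonded chain carbon bound to a double-bonded ring carbon proves sensitive to the aromatic group: naphthalen-2-yl in place of 4-bromophenyl gives a 14-fold higher number from compound 2 to compound 3 (1.13 log units; beyond the scatter) and naphthalen-2-yl in place of 4-chlorophenyl gives a 22-fold higher number from compound 1 to compound 3 (1.34 log units; beyond the scatter) and both steps are large. The exchange of one halogen for the other had shown no change beyond the scatter, so this is the first clear loss of activity at this place. Nothing at hand accounts for that loss. The compounds shown do not separate the removal of the halogen from the addition of a second six-membered aromatic ring, as both occur together in compound 3. From the compounds shown here alone, whether an unsubstituted phenyl or a 4-methoxyphenyl would stay with the halogenated compounds remains open.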